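This account rests on a few compounds, and the source may have more. Where it says the series, first, only, none or still open, it means among the compounds named here.

Of the compounds shown here, two built on the same core have been tested so far. Compound 1 `COC(=O)[C@@]1(C)CC[C@@H]2C3=C1CC[C@@H](C)[C@]3(C)C[C@@H]1c3ccccc3N[C@H]21` and compound 2 `COC(=O)[C@@]1(C)CC[C@@H]2C3=C1CC[C@@H](C)[C@]3(C)C[C@@H]1c3cc(C)ccc3N[C@H]21` differ in a single group on one aromatic carbon. In a functional assay on T47D cells (Homo sapiens) for inhibition, read by sulforhodamine B assay, with a stated time of 48 h (on this read-out higher numbers stand for weaker inhibition of growth and lower numbers for stronger inhibition of growth), compound 1 gives 35000 nM, while compound 2 gives 23000 nM. Compound 2 shows the lower of the two numbers, but the step of a 1.5-fold lower number from compound 1 to compound 2 (0.18 log units; within the scatter) means the two values cannot be told apart. Compound 3 `COC(=O)[C@@]1(C)CC[C@@H]2C3=C1CC[C@@H](C)[C@]3(C)C[C@@H]1c3cc(Br)ccc3N[C@H]21` is the next candidate; compared with compound 2 it carries bromo in place of methyl on an aromatic carbon. For the measured compounds named here, the only measured step that bears on this change is a 1.5-fold lower number from compound 1 to compound 2 (0.18 log units; within the scatter), an exchange of groups at the very same aromatic carbon that stayed within the scatter. A further swap of one small group for another at that carbon is therefore expected to give no step beyond the scatter in this assay. Compound 3 is estimated to show a 1.2-fold lower number from compound 2 to compound 3 (0.06 log units; within the scatter), with a value near 20000 nM and a likely range from 8000 nM to 50000 nM.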

Compound 3, concentration for 50% growth inhibition: 31000 nM
Estimate against measurement, compound 3: 1.6-fold (0.19 log units) below; low and high end bracket the measured number.
By their numbers in this assay, from the lowest: compounds 2, 3 and 1 (each within the scatter of the next).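

In this assay, bromo at this aromatic carbon gives a 1.3-fold higher number from compound 2 to compound 3 (0.13 log units; within the scatter) against methyl and a 1.1-fold lower number from compound 1 to compound 3 (0.05 log units; within the scatter) against hydrogen, and both steps lie within the scatter. Where the earlier compounds offered a single comparison, hydrogen, methyl and bromo now form a set of three groups at the same carbon, and no two of them can be told apart in this assay. No supporting measurement is available that would tie this result to any property of these groups.

Going by these compounds, it remains open whether a different kind of group at this carbon, such as an amine, a carboxylic acid or a longer chain, would give a step beyond the scatter. These compounds also cannot show how changes elsewhere on the aromatic ring or the shared core would affect growth inhibition.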